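A few compounds are considered here, and "the series" means these few. Any claim that something is new, unique, unknown or untested is made for them only; others in the source may bear on it.

In a toxicity assay on THP-1 cells (Homo sapiens) for inhibition (on this read-out higher numbers stand for lower toxicity in this test and lower numbers for higher toxicity in this test), compound 1 `Cn1c(-c2ccccc2)cnc1NC(=O)c1ccc(F)cc1` gives > 100000 nM as a limit of the assay, not a number. Compound 2 `Cn1c(-c2ccccc2Cl)cnc1NC(=O)c1ccc(F)cc1` gives > 50000 nM as a limit as well. Compound 3 `Cn1c(-c2cccc([N+](=O)[O-])c2)cnc1NC(=O)c1ccc(F)cc1` likewise gives > 50000 nM as a limit. Compound 1 therefore stands only at a limit, and so does the rest of the measured set: the limit of > 100000 nM in this assay, at which 1 of the 3 values shown sits, and the limit of > 50000 nM in this assay, at which 2 of the 3 values shown sit, account for all of it.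

Compound 4 `Cn1c(-c2ccccc2)cnc1NC(=O)c1ccc(Cl)cc1` is still to be measured. It departs from compound 1 by chloro in place of fluoro on an aromatic carbon in the change from 4-fluorophenyl to 4-chlorophenyl, chloro in place of fluoro on an aromatic carbon. The measured steps that bear on it are a step that the two limits leave unreadable from compound 1 to compound 2 and a step that the two limits leave unreadable from compound 1 to compound 3 and neither gives a size. Among the measured compounds shown here, both put chloro or nitro in place of hydrogen, and no measured step replaces fluoro. No step beyond the scatter is expected in this assay and no direction can be given. The estimated step is an at least 1.2-fold lower number from compound 1 to compound 4 (0.09 log units; that floor lies within the scatter) and it is expected to stay within the scatter. For compound 4 the expected value is 80000 nM with an estimated range of 30000 nM to 150000 nM and a report as a limit is likely.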

Compound 4, half-maximal cytotoxic concentration: > 100000 nM
Compound 4: only a limit was reported (the forecaster's own chance of this, stated with the estimate: 85%); at least 1.2-fold (0.09 log units) between middle value and limit.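

No step can be read from compound 1 to compound 4 in this assay, because both values are limits and not numbers: the limit of > 100000 nM in this assay, at which 2 of the 4 values shown sit.

The compounds shown leave open how far any of the four lies from its limit, and so whether chloro in place of fluoro alters this read-out.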